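Trimming the tert-butyl of compound 1 to isopropyl

The source may hold more compounds than are shown below. What is called first, only, known or untested is meant among the compounds shown, and "the series" means these compounds.

Measured so far:
compound 1, `CC(C)(C)c1cc(NC(=O)c2ccc(Cl)cc2Cl)ccc1O`, 13600 nM
compound 2, `CC(C)(C)c1cc(NC(=O)c2ccc(Cl)cc2Cl)cc(C(C)(C)C)c1O`, > 100000 nM

Within the data shown here, compound 1 is the only compound of the pair with a number in an assay on isolated protein for antagonist activity at Bile acid receptor (Homo sapiens), read by HTRF, with a stated time of 30 min; on this read-out higher numbers stand for weaker inhibition and lower numbers for stronger inhibition; compound 2 gives only a limit of the assay, > 100000 nM, so compound 1 stands as the sole reference point. Among the measured compounds shown here, the one measured step, an at least 7.3-fold higher number from compound 1 to compound 2 (0.86 log units; beyond the scatter), adds a second tert-butyl to the shared core; it is at least modest in size, and the value reached is a limit, (the limit of > 100000 nM in this assay, at which 1 of the 2 values shown sits).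

Compound 3, `CC(C)c1cc(NC(=O)c2ccc(Cl)cc2Cl)ccc1O`, differs from compound 1 by hydrogen in place of methyl on a saturated chain carbon bound to an aromatic carbon and two saturated chain carbons; seen one bond further out, the change reads tert-butyl to isopropyl. For the measured compounds named here, no measured step removes part of this group, and the step to compound 2 adds rather than removes, so it bears only loosely on the present change. The expectation is therefore a step no larger than the scatter, a 1.3-fold higher number from compound 1 to compound 3 (0.12 log units; within the scatter), with a small lean toward weaker inhibition. The estimated value for compound 3 in this assay is 18000 nM, within 7000 nM to 50000 nM.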

Compound 3, half-maximal inhibitory concentration: > 100000 nM
Compound 3 was reported as a limit (the forecaster's own chance of this, stated with the estimate: 10%); at least 5.5-fold (0.74 log units) between middle value and limit.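

In this assay, the tert-butyl of compound 1 does not tolerate trimming: hydrogen in place of methyl on a saturated chain carbon bound to an aromatic carbon and two saturated chain carbons, which turns tert-butyl into isopropyl, gives an at least 7.3-fold higher number from compound 1 to compound 3 (0.86 log units; beyond the scatter). Compound 3 gives > 100000 nM, which is a limit of the assay, so the loss of one methyl is enough to take the series out of the measurable range, and this holds for a change within the group itself rather than for the added second tert-butyl of compound 2. Compound 1 is thus the only compound with a number, and both single changes made to it end at the same limit: the limit of > 100000 nM in this assay, at which 2 of the 3 values shown sit.

As far as these compounds go, the true size of the step to compound 3 stays open, and compound 2 and compound 3 cannot be ordered against each other. Also open, from the compounds shown here alone, is what a cyclopropyl, a trifluoromethyl or a longer chain would give in place of the tert-butyl, and whether any group there improves on compound 1.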